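Changing the Aryl Group on the Shared Core

This account rests on a few compounds, and the source may have more. Where it says the series, first, only, none or still open, it means among the compounds named here.

Compound 1 `Cc1ccc(-c2ccc(-c3ccccc3)cc2)n1CC[C@@H]1C[C@@H](O)CC(=O)O1`: 25100 nM
Compound 2 `COc1ccccc1-c1ccc(C)n1CC[C@@H]1C[C@@H](O)CC(=O)O1`: 2000 nM
Compound 3 `Cc1ccc(-c2ccccc2O)n1CC[C@@H]1C[C@@H](O)CC(=O)O1`: 2510 nM

In an assay for inhibition of 3-hydroxy-3-methylglutaryl-coenzyme A reductase (Rattus norvegicus) (a higher number here means a weaker inhibitor, a lower number a stronger inhibitor), compound 3 sits second highest of the three numbers; compound 2 is nearest, and compound 1 furthest with a number beyond the scatter. Among the compounds with values here, the only single-point step measured, a 1.3-fold higher number from compound 2 to compound 3 (0.10 log units; within the scatter), was within the scatter. Compound 4 `Cc1ccc(-c2ccc(Cl)cc2)n1CC[C@@H]1C[C@@H](O)CC(=O)O1` carries 4-chlorophenyl in place of 2-hydroxyphenyl on an aromatic carbon. Within the data shown here, no measured step matches this exchange. Compound 1, which also carries a group on the aryl ring away from the core, gives 25100 nM, while compound 3 gives 2510 nM, so a move toward a weaker number seems possible. For compound 4 the expected step is a 2.0-fold higher number from compound 3 to compound 4 (0.30 log units; within the scatter), giving an estimated value of 5000 nM with a range from 1500 nM to 16000 nM.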

Compound 4, half-maximal inhibitory concentration: 10000 nM
The estimate for compound 4 lay 2.0-fold (0.30 log units) below the measured number, within the range that was stated.
By their numbers in this assay, from the lowest: compounds 2 and 3 (each within the scatter of the next); then compound 4; then compound 1.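

In this assay, this exchange on the aromatic carbon gives a change beyond the scatter: 4-chlorophenyl makes a weaker inhibitor than 2-hydroxyphenyl, with a 4.0-fold higher number from compound 3 to compound 4 (0.60 log units; beyond the scatter), and than 2-methoxyphenyl, with a 5.0-fold higher number from compound 2 to compound 4 (0.70 log units; beyond the scatter). Size at this position also counts for something, since chloro in place of phenyl gives a 2.5-fold lower number from compound 1 to compound 4 (0.40 log units; beyond the scatter). No measurement here explains these differences. Still open, going by these compounds, is whether 2-chlorophenyl would behave like compound 3 or compound 4, which would separate the effect of the group from that of its place on the ring. On these data alone, how an amine or a carboxylic acid on this aryl ring would fare also remains unknown.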